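A Hydroxy for a Tert-Butyl in a Urea Series

The compounds below may be only part of what the source reports. "The series", "measured", "known", "first", "only" and "open" are said of these compounds alone.

Of the compounds shown here, three sharing one core have been measured in an ADME assay for permeability, using PAMPA, at pH 7.4; a higher number here means that the compound crosses the layer faster, a lower number that the compound crosses the layer more slowly. Compound 1 `Cc1cc(NC(=O)Nc2ccc(C(C)(C)C)cc2)c2ccccc2n1` gives 142 10^-6 cm/s, the lowest of the three. Compound 2 `COc1ccc(NC(=O)Nc2cc(C)nc3ccccc23)cc1OC` gives 552 10^-6 cm/s, and compound 3 `Cc1cc(NC(=O)Nc2ccc(F)c(F)c2)c2ccccc2n1` gives 478 10^-6 cm/s; both stand well above compound 1, beyond the scatter of the method.

The next compound to be measured is compound 4 `Cc1cc(NC(=O)Nc2ccc(O)cc2)c2ccccc2n1`. It differs from compound 1 in a single place: hydroxy in place of tert-butyl on an aromatic carbon. Among the measured compounds shown here, no pair of measured compounds shows this exact change, so its effect cannot be read off directly. Because compound 2 carries a group other than tert-butyl and gives 552 10^-6 cm/s, and because compound 3 likewise gives 478 10^-6 cm/s, both values above compound 1, the step from tert-butyl to another group has so far gone upward, and a modest upward step, possibly still inside the scatter, is expected here as a 1.5-fold higher number from compound 1 to compound 4 (0.19 log units; within the scatter). Compound 4 is accordingly estimated at 220 10^-6 cm/s, with a likely range from 90 10^-6 cm/s to 520 10^-6 cm/s.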

Compound 4, apparent permeability: 3 10^-6 cm/s
Estimate against measurement, compound 4: 73-fold (1.87 log units) above; the whole stated range lies above it.
By their numbers in this assay, from the lowest: compound 4; then compound 1; then compounds 3 and 2 (each within the scatter of the next).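

Within the shared core, in this assay, hydroxy in place of tert-butyl on an aromatic carbon gives a 47-fold lower number from compound 1 to compound 4 (1.68 log units; beyond the scatter) as the first step between two compounds that differ in one place. The earlier compounds shown here offered no such pair, so they could not isolate what this aromatic carbon contributes. This single change now shows that the group there can move the read-out a long way, and that the move for this exchange is downward, not the upward one the earlier values seemed to suggest. Nothing measured here explains why the step is so large.

Among the compounds shown here, with only this pair, the drop cannot be assigned to losing tert-butyl or to gaining hydroxy. An amine or an ethyl group on the same aromatic carbon would help to separate those two readings.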